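The compounds below may be only part of what the source reports. "The series", "measured", "known", "first", "only" and "open" are said of these compounds alone.

Compounds measured so far in a functional assay on PC-3 cells (Homo sapiens) for cytotoxicity, read by MTT assay, with a stated time of 72 h; a lower number here means a stronger inhibitor, a higher number a weaker inhibitor:
compound 1 `CCCCCCNc1nc(SCc2ccc(C(F)(F)F)cc2)nc2ccccc12`: 19000 nM
compound 2 `FC(F)(F)c1ccc(CSc2nc(Nc3cccc(Cl)c3)c3ccccc3n2)cc1`: 13400 nM
compound 3 `O=[N+]([O-])c1cccc(Nc2nc(SCc3ccc(C(F)(F)F)cc3)nc3ccccc23)c1`: 13500 nM

Compound 3 sits within the scatter of both other numbers, nearest compound 2 a 1.0-fold higher number from compound 2 to compound 3 (0.00 log units; within the scatter) and a little apart from compound 1 a 1.4-fold lower number from compound 1 to compound 3 (0.15 log units; within the scatter). The step to compound 4 `COc1cc(Nc2nc(SCc3ccc(C(F)(F)F)cc3)nc3ccccc23)cc(OC)c1` is 3,5-dimethoxyphenyl in place of 3-nitrophenyl on a nitrogen on an aromatic ring. Within the data shown here, the steps that bear on it are those at the same nitrogen: a 1.4-fold lower number from compound 1 to compound 2 (0.15 log units; within the scatter) and a 1.4-fold lower number from compound 1 to compound 3 (0.15 log units; within the scatter), and the swap on the ring, a 1.0-fold higher number from compound 2 to compound 3 (0.00 log units; within the scatter). Three different groups at that position have given numbers within the scatter of one another, so no step beyond the scatter is expected for a 1.0-fold lower number from compound 3 to compound 4 (0.02 log units; within the scatter). Compound 4 is estimated at 13000 nM, with a range from 6000 nM to 30000 nM.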

Compound 4, half-maximal inhibitory concentration: > 50000 nM
Compound 4 ended at the assay's limit; the forecaster's own chance of this, stated with the estimate: 10%; middle value at least 3.8-fold (0.58 log units) away from the limit.
By their numbers in this assay, from the lowest: compounds 2, 3 and 1 (each within the scatter of the next). At a limit, above all of these: compound 4.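

In this assay compound 4 gives > 50000 nM, which is a limit of the assay and not a number: the limit of > 50000 nM in this assay, at which 1 of the 4 values shown sits. The substituent on this nitrogen had made no difference beyond the scatter across hexyl, 3-chlorophenyl and 3-nitrophenyl, but now it does: an at least 3.7-fold higher number from compound 3 to compound 4 (0.56 log units; beyond the scatter), an at least 3.7-fold higher number from compound 2 to compound 4 (0.57 log units; beyond the scatter) and an at least 2.6-fold higher number from compound 1 to compound 4 (0.42 log units; beyond the scatter). Of the four groups, only 3,5-dimethoxyphenyl stands apart, and it gives the weakest inhibitor of the series.

On these data alone, whether this shift needs both methoxy groups or follows from a phenyl carrying just one remains open. Also open, as far as these compounds go, is how a phenyl carrying an amine or a carboxylic acid would read at this nitrogen.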